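Swapping dimethylamino for neopentylamino on a pyrimidine-based agonist

This account rests on a few compounds, and the source may have more. Where it says the series, first, only, none or still open, it means among the compounds named here.

Two compounds share a core that carries a pyridin-2-yl group and are tested in a functional assay on HEK293 cells for agonist activity at G-protein coupled receptor 39 (Homo sapiens), read by inositol phosphate accumulation; a higher number here means that more compound is needed for the effect, a lower number that less compound is needed. Compound 1 `CNc1nc(NCc2ccc(N(C)C(C)=O)cc2)cc(-c2ccccn2)n1` gives 1180 nM. Compound 2 `CN(C)c1nc(NCC2CC2)cc(-c2ccccn2)n1` reaches only the limit of the assay, > 25000 nM, so no number is known for it. Its value sits at the limit of > 25000 nM in this assay, at which 1 of the 2 values shown sits. Going by the values given here, compound 2 thus stands at the weak end of what has been seen, while compound 1 is the only compound with a measured number.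

Compound 3 `CC(C)(C)CNc1nc(NCC2CC2)cc(-c2ccccn2)n1` has not yet been measured. It differs from compound 2 in one place: neopentylamino in place of dimethylamino on an aromatic carbon. Among the compounds with values here, the group that enters brings one hydrogen-bond donor, which the dimethylamino group that leaves does not have; compound 1, the one compound with a measured value, also carries a group with one hydrogen-bond donor at that position. Beyond that, no measured step links these compounds, so any expectation rests on these two values alone.

The change from compound 2 to compound 3 is expected to be a step toward less compound needed, of size an at least 6.2-fold lower number from compound 2 to compound 3 (0.79 log units; beyond the scatter). Compound 3 is estimated at 4000 nM, within a range of 800 nM to 25000 nM.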

Compound 3, half-maximal effective concentration: 5000 nM
Estimate against measurement, compound 3: 1.3-fold (0.10 log units) below; measured number inside the range.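

On the aromatic carbon between two ring nitrogen atoms, putting neopentylamino in place of dimethylamino gives, in this assay, an at least 5.0-fold lower number from compound 2 to compound 3 (0.69 log units; beyond the scatter). Going by these compounds alone, this is the first measured sign that the group at this position matters on its own, since the rest of the molecule stays the same, and that neopentylamino, the larger group by heavy atoms, still allows a measurable response. The full size of the step stays unknown because compound 2 has only a limit and not a number: the limit of > 25000 nM in this assay, at which 1 of the 3 values shown sits.

The change adds a hydrogen-bond donor and extra heavy atoms in one move, so these compounds cannot tell which of the two goes with the lower number. A plain amino group or an ethylamino group at this position would keep the donor with fewer heavy atoms, while a pyrrolidine group would have no such donor, and the compounds shown leave open how any of these would compare with neopentylamino on the same (cyclopropylmethyl)amino background.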